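The source may hold more compounds than are shown below. What is called first, only, known or untested is meant among the compounds shown, and "the series" means these compounds.

Measured so far:
compound 1 `CCCCSc1cc2ccccc2nc1N` with 4160 nM in an assay on HEK-Blue hTLR8 cells for agonist activity at Toll-like receptor 8 (Homo sapiens), read by reporter gene assay and spectrophotometry; a lower number here means that less compound is needed, a higher number that more compound is needed for the effect
compound 2 `CCCCNc1cc2ccccc2nc1N` with 4280 nM in this assay

Compound 2 gives the higher of the two numbers, yet the step of a 1.0-fold higher number from compound 1 to compound 2 (0.01 log units; within the scatter) shows that exchanging butylsulfanyl for butylamino on the shared core left the read-out unchanged. Compound 3 `CCC/C=C/c1cc2ccccc2nc1N` carries the change (pent-1-en-1-yl in place of butylamino on an aromatic carbon); the butylamino group, with its one hydrogen-bond donor and one acceptor, gives way to a five-carbon chain that holds one double bond outside the aromatic rings and no donor or acceptor, at the position ortho to an amino group on the shared core.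

Within the data shown here, the only step that bears on this, a 1.0-fold higher number from compound 1 to compound 2 (0.01 log units; within the scatter), was within the scatter, so a change of the linking atom in this place did not move the number. On that basis compound 3 is expected to stay close to compound 2, with a 1.0-fold lower number from compound 2 to compound 3 (0.01 log units; within the scatter) estimated as no change beyond the scatter. The estimate for compound 3 in this assay is 4200 nM, in the range 1500 nM to 12000 nM.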

Compound 3, half-maximal effective concentration: 2670 nM
Estimate against measurement, compound 3: 1.6-fold (0.20 log units) above; measured number inside the range.
By their numbers in this assay, from the lowest: compounds 3, 1 and 2 (each within the scatter of the next).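

In this assay, both a 1.6-fold lower number from compound 2 to compound 3 (0.20 log units; within the scatter) and a 1.6-fold lower number from compound 1 to compound 3 (0.19 log units; within the scatter) stay within the scatter, so the result extends the earlier finding beyond a change of linking atom. At this place on the shared core, pent-1-en-1-yl, with its double bond outside the aromatic rings and no hydrogen-bond donor or acceptor, gives a number within the scatter of those of the butylamino and butylsulfanyl compounds, so the donor and acceptor of butylamino are not needed to keep the number there. No independent evidence is available to explain this result.

The compounds shown leave open whether a saturated pentyl chain, without the double bond, would behave in the same way. They also leave open whether a longer chain, or a chain ending in an amine, would move the number beyond the scatter.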